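Amino in Place of Nitro on a Second Core

This account rests on a few compounds, and the source may have more. Where it says the series, first, only, none or still open, it means among the compounds named here.

Compound 1 `COc1ccc(-c2cnnn2Cc2cc(OC)c(OC)c(OC)c2)cc1[N+](=O)[O-]` and compound 2 `COc1ccc(-c2cnnn2Cc2cc(OC)c(OC)c(OC)c2)cc1N` share one core and differ by amino in place of nitro on an aromatic carbon. In a functional assay on K562 cells (Homo sapiens) for cytotoxicity, read by MTT assay, with a stated time of 5 days (a lower number here means a stronger inhibitor, a higher number a weaker inhibitor), compound 1 gives only a limit, > 10000 nM. In this assay compound 2 gives 380 nM. The step of an at least 26-fold lower number from compound 1 to compound 2 (1.42 log units; beyond the scatter) is itself only a bound, since compound 1 sits at the limit of > 10000 nM in this assay, at which 2 of the 3 values shown sit.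

Compound 3 `COc1ccc(Cn2cc(-c3cc(OC)c(OC)c(OC)c3)nn2)cc1[N+](=O)[O-]` has the same atoms as compound 1 joined differently; the difference between the two cores is not broken down here. In this assay compound 3 gives only a limit, > 10000 nM. Compound 4 `COc1ccc(Cn2cc(-c3cc(OC)c(OC)c(OC)c3)nn2)cc1N` differs from compound 3 by amino in place of nitro on an aromatic carbon, the same change as from compound 1 to compound 2.

For compound 4 a step of an at least 6.6-fold lower number from compound 3 to compound 4 (0.82 log units; beyond the scatter) in this assay is expected, resting on the step of an at least 26-fold lower number from compound 1 to compound 2 (1.42 log units; beyond the scatter). Compound 4 is therefore estimated at 1500 nM in this assay, between 200 nM and 10000 nM.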

Compound 4, half-maximal inhibitory concentration: > 10000 nM
Compound 4: no number, only a limit (the forecaster's own chance of this, stated with the estimate: 35%); at least 6.6-fold (0.82 log units) between middle value and limit.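

The step from compound 3 to compound 4 cannot be read, as each gives only a limit: the limit of > 10000 nM in this assay, at which 3 of the 4 values shown sit.

The compounds shown leave open whether amino in place of nitro lowers the number on the core of compound 3 as it does on the core of compound 1.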